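Swapping tert-butyl for methyl in an inactive series

The source may report more compounds than this note shows. Statements on the series, on what has been measured and on what is new or still open speak of the compounds shown alone.

Compound 1, `O=C1NC(O)(CCn2cc(C3=CCCCC3)nn2)C(OCc2ccccc2)=C1OCc1ccccc1`, in a functional assay on HCT-116 cells (Homo sapiens) for antiproliferative activity, read by MTT assay, with a stated time of 24 h (on this read-out lower numbers stand for stronger inhibition and higher numbers for weaker inhibition), reaches only an assay limit, > 100000 nM.
Compound 2, `CC(C)(C)c1ccc(-c2cn(CCC3(O)NC(=O)C(OCc4ccccc4)=C3OCc3ccccc3)nn2)cc1`, in this assay likewise reaches only an assay limit, > 100000 nM.

For the measured compounds named here, compound 2 therefore stands at the limit of this assay, with no measured number at all; the only other value shown is also a limit. Going by the values given here, the one measured step, a step that the two limits leave unreadable from compound 1 to compound 2, cannot be sized, because the limit of > 100000 nM in this assay, at which 2 of the 2 values shown sit, places both ends of that step at the same limit. So there is no readable step that bears on the change to compound 3, `Cc1ccc(-c2cn(CCC3(O)NC(=O)C(OCc4ccccc4)=C3OCc3ccccc3)nn2)cc1`, which differs from compound 2 by methyl in place of tert-butyl on an aromatic carbon. With compound 2 already outside the measurable range, no direction can be drawn from the data; the step that the limit leaves unreadable from compound 2 to compound 3 is expected to be none beyond the scatter, and compound 3 is most likely to return another limit. Compound 3 is estimated at 150000 nM in this assay, with a range from 40000 nM to 500000 nM.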

Compound 3, half-maximal inhibitory concentration: 74300 nM
Compound 3: middle estimate off by 2.0-fold (0.31 log units), on the high side; measured number inside the range.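

In this assay compound 3 gives 74300 nM as a true measured number, the first in this set, so a 4-methylphenyl group brings the series just inside the range the test can measure. Putting methyl in place of tert-butyl on this aromatic carbon gives an at least 1.3-fold lower number from compound 2 to compound 3 (0.12 log units; that floor lies within the scatter) and replacing cyclohex-1-en-1-yl with 4-methylphenyl gives an at least 1.3-fold lower number from compound 1 to compound 3 (0.12 log units; that floor lies within the scatter) on the same reading, so neither step can yet be claimed as a real gain, although the true gap in each could be larger than this floor. The step between compound 1 and compound 2 still cannot be read, and the real size of the two new steps stays hidden, with one end of each resting on a limit rather than a number: the limit of > 100000 nM in this assay, at which 2 of the 3 values shown sit.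

From the compounds shown here alone, it remains open whether the group at this spot truly governs the activity, and whether a plain hydrogen, a methoxy group or an amine in the same place would push the number clearly lower. Also open, going by these compounds, is whether the series would respond more strongly to a change elsewhere, such as a free hydroxyl or a carboxylic acid in place of the benzyl groups on the shared core.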